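A few compounds are considered here, and "the series" means these few. Any claim that something is new, unique, unknown or untested is made for them only; others in the source may bear on it.

Compound 1 `Nc1ccccc1NC(=O)CCCCCN(CC(=O)NC1CCCCC1)C(=O)c1ccccc1` is the weakest of the three compounds measured in a functional assay on A2780 cells (Homo sapiens) for cytotoxicity, read by MTT assay, with a stated time of 72 h; on this read-out higher numbers stand for weaker inhibition and lower numbers for stronger inhibition: compound 1 gives 181000 nM, and both of its companions lie beyond the scatter below it. Compound 3 `CN(C)c1ccc(C(=O)N(CCCCCC(=O)Nc2cc(F)ccc2N)CC(=O)NCc2ccccc2)cc1` stands nearest, giving 25900 nM in this assay, and compound 2 `Nc1ccccc1NC(=O)c1ccc(CN(CC(=O)NCc2ccccc2)C(=O)c2cccnc2)cc1` stands furthest, giving 8900 nM in this assay. Within the data shown here, neither compound 2 nor compound 3 differs from compound 1 in a single place, so no single-change step can be drawn among the measured compounds.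

The step of interest leads to compound 4 `Nc1ccccc1NC(=O)CCCCCN(CC(=O)NC1CCCCC1)C(=O)c1cccc2ccccc12`, which has not been measured. Relative to compound 1 the change is naphthalen-1-yl in place of phenyl on a carbonyl carbon. The aromatic ring on the carbonyl carbon grows from one six-membered ring to two, with no change in donors, acceptors or charge.

Among the measured compounds shown here, no measured pair in this set shows what such a change does, so the expectation rests on the change itself and on the weak starting point of compound 1. The step is expected to be a modest one toward a lower number, a 1.6-fold lower number from compound 1 to compound 4 (0.22 log units; within the scatter), and it may well fall within the scatter. Compound 4 is therefore estimated at 110000 nM in this assay, within a range from 40000 nM to 300000 nM.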

Compound 4, half-maximal inhibitory concentration: 18100 nM
Compound 4: middle estimate off by 6.1-fold (0.78 log units), on the high side; measured number outside the range, below it.
By their numbers in this assay, from the lowest: compound 2; then compounds 4 and 3 (each within the scatter of the next); then compound 1.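

In this assay, among these compounds, the step at the carbonyl carbon whose other neighbour is the amide-type nitrogen reads a 10-fold lower number from compound 1 to compound 4 (1.00 log units; beyond the scatter) for naphthalen-1-yl in place of phenyl, so this is the first single change in the set whose size can be read at all. It shows that this position is not indifferent to the aromatic group it carries: a second six-membered aromatic ring of carbon only moves the number beyond the scatter, although donors, acceptors and charge stay as they were. What lies behind the step cannot be said, as nothing measured here speaks to it.

Still open, going by these compounds, is whether the step belongs to the naphthalen-1-yl group itself or would also appear with naphthalen-2-yl, with quinolin-8-yl, which brings a ring nitrogen, or with a biphenyl-4-yl group. The compounds shown also leave open whether the same replacement would give a step of similar size on the core of compound 2 or of compound 3, where the groups around this carbonyl differ.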